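A few compounds are considered here, and "the series" means these few. Any claim that something is new, unique, unknown or untested is made for them only; others in the source may bear on it.

Measured compounds:
compound 1 `Cc1ccc(NC(=O)c2ccc(F)cc2)cc1-n1cc(-c2cnc3cccnn23)cn1` with 12400 nM
compound 2 `Cc1ccc(NC(=O)c2cccc(Cl)c2)cc1-n1cc(-c2cnc3cccnn23)cn1` with 5080 nM

The study covers two measured compounds that share one core and differ only in the aryl group on the carbonyl carbon. In a functional assay on K562 cells (Homo sapiens) for antiproliferative activity, read by CCK-8 assay, with a stated time of 24 h (a higher number here means a weaker inhibitor, a lower number a stronger inhibitor), compound 1 gives 12400 nM, and compound 2 gives 5080 nM. Compound 2 thus holds the lowest of the two numbers in this assay, and the step of a 2.4-fold lower number from compound 1 to compound 2 (0.39 log units; beyond the scatter) lies beyond the scatter, although it is modest.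

Compound 3 `CCc1ccc(C(=O)Nc2ccc(C)c(-n3cc(-c4cnc5cccnn45)cn3)c2)cc1` is the next member. Relative to compound 2 the change is 4-ethylphenyl in place of 3-chlorophenyl on a carbonyl carbon. Going by the values given here, no measured step covers this exchange directly; the only measured step, a 2.4-fold lower number from compound 1 to compound 2 (0.39 log units; beyond the scatter), swaps one halogenated phenyl for another and bears on it loosely at best. It shows that the aryl group on the carbonyl carbon can shift this assay by a modest amount, but it gives no direction for an alkyl group. The author therefore expects for compound 3 a step of about a 1.2-fold higher number from compound 2 to compound 3 (0.07 log units; within the scatter), which is within the scatter. The estimate for compound 3 in this assay is 6000 nM, with a plausible range from 2500 nM to 15000 nM.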

Compound 3, half-maximal inhibitory concentration: 7540 nM
Compound 3: the middle estimate sits 1.3-fold (0.10 log units) below what was measured; measured number inside the range.
By their numbers in this assay, from the lowest: compounds 2, 3 and 1 (each within the scatter of the next, the first and the last beyond it).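

Going by these compounds alone, compound 3 is the first member with an alkyl group rather than a halogen on the phenyl ring attached to the carbonyl carbon, and in this assay this exchange gives a 1.5-fold higher number from compound 2 to compound 3 (0.17 log units; within the scatter). Measured against the other halogenated member, the same position gives a 1.6-fold lower number from compound 1 to compound 3 (0.22 log units; within the scatter), so compound 3 cannot be separated from either compound 1 or compound 2, although those two lie apart from each other with a 2.4-fold lower number from compound 1 to compound 2 (0.39 log units; beyond the scatter). At this position, then, 4-ethylphenyl gives a number that falls within the scatter of both halogenated phenyl groups, and nothing in the available data accounts for these numbers.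

The three compounds carry only chloro, fluoro and ethyl on this phenyl ring, so they leave open how an amine, a carboxylic acid or a longer chain such as butyl would read in this assay. They also cannot show whether any exchange at this position would bring a step much larger than those seen here, or whether changes elsewhere on the shared core would matter more.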